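The compounds below may be only part of what the source reports. "The series", "measured", "known", "first", "only" and "open" are said of these compounds alone.

Compound 1, `C=CCSC[C@H](NC(=O)c1cc(OC)c(OC)c(OC)c1)C(=O)OC`: 49300 nM
Compound 2, `C=CCCSC[C@H](NC(=O)c1cc(OC)c(OC)c(OC)c1)C(=O)OC`: 27300 nM
Compound 3, `C=CCSC[C@H](NC(=O)c1cc(O)cc(O)c1)C(=O)OC`: 58500 nM

All three were tested in an assay on RAW264.7 cells for antagonist activity at Toll-like receptor 2 (Mus musculus), read by Griess assay, with a stated time of 24 h; a lower number here means a stronger inhibitor, a higher number a weaker inhibitor. Compound 1 and compound 2 share one core and differ in a single place: allyl in place of vinyl on a saturated chain carbon bound to a sulfur. That change gave a 1.8-fold lower number from compound 1 to compound 2 (0.26 log units; within the scatter), so it counts as a small step. Compound 3 is built on another core; the difference between the core of compound 1 and the core of compound 3 is not broken down here. In this assay the number for compound 3 lies within the scatter of the number for compound 1, while the gap from compound 3 to compound 2 lies beyond the scatter.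

Compound 4, `C=CCCSC[C@H](NC(=O)c1cc(O)cc(O)c1)C(=O)OC`, has not yet been measured. It relates to compound 3 as compound 2 relates to compound 1: allyl in place of vinyl on a saturated chain carbon bound to a sulfur. The place is described in the same words for both pairs, so this is the same change, now made on the second core. Among the compounds with values here, the expected step is a 1.8-fold lower number from compound 3 to compound 4 (0.26 log units; within the scatter), a shift of about the size seen before, because the only example of this change gave a 1.8-fold lower number from compound 1 to compound 2 (0.26 log units; within the scatter). That expectation rests on a single pair, and that pair moved only within the scatter, so the range is kept wide. Compound 4 is therefore expected to give 32000 nM in this assay, with a likely range from 18000 nM to 60000 nM.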

Compound 4, half-maximal inhibitory concentration: 35800 nM
For compound 4 the middle estimate is 1.1-fold (0.05 log units) below the measured one, and the stated range covers the measured number.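

In this assay, putting allyl in place of vinyl on a saturated chain carbon bound to a sulfur gave a 1.6-fold lower number from compound 3 to compound 4 (0.21 log units; within the scatter), and this result can be set directly beside the same change on the other core: the same change on two cores in this assay, a 1.8-fold lower number (0.26 log units; within the scatter) from compound 1 to compound 2 and a 1.6-fold lower number (0.21 log units; within the scatter) from compound 3 to compound 4, 1.1-fold (0.04 log units) apart, within the scatter of two such steps. In this small series, the change therefore carried from the core of compound 1 to the core of compound 3 with a step of much the same size, and the new core did not visibly alter its outcome. This does not show that the change itself has a real effect on the read-out, as each step taken alone lies within the scatter, and two cores cannot show how it would behave on a third.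

The compounds shown leave open how a longer chain on the sulfur, such as pent-4-en-1-yl, or a saturated butyl chain with no double bond, would read in this assay. They also leave open what a carboxylic acid in place of the methyl ester would do, and whether any change at these places can produce a step that clearly rises above the scatter.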